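Aryl Exchange Repeated on the Shorter Chain

The source may hold more compounds than are shown below. What is called first, only, known or untested is meant among the compounds shown, and "the series" means these compounds.

Four compounds share one core and differ in two places. Compound 1 `CCCCCCn1cnc2c(Nc3ccc(Cl)cc3)nc(N[C@H]3CC[C@H](N)CC3)nc21`, compound 2 `CCCCCCn1cnc2c(Nc3cc(OC)cc(OC)c3)nc(N[C@H]3CC[C@H](N)CC3)nc21` and compound 3 `CCCCn1cnc2c(Nc3cc(OC)cc(OC)c3)nc(N[C@H]3CC[C@H](N)CC3)nc21` have been measured in a functional assay on K562 cells (Homo sapiens) for inhibition, read by fluorescence, with a stated time of 72 h (a lower number here means a stronger inhibitor of growth, a higher number a weaker inhibitor of growth), while compound 4 `CCCCn1cnc2c(Nc3ccc(Cl)cc3)nc(N[C@H]3CC[C@H](N)CC3)nc21` has not. In this assay compound 1 gives 2100 nM, compound 2 gives 1900 nM and compound 3 gives 2400 nM. Compound 2 and compound 3 differ by hydrogen in place of ethyl on a saturated chain carbon, four bonds along the chain from an aromatic nitrogen, a change that gave a 1.3-fold higher number from compound 2 to compound 3 (0.10 log units; within the scatter). Compound 2 and compound 1 differ by 4-chlorophenyl in place of 3,5-dimethoxyphenyl on a nitrogen on an aromatic ring, which gave a 1.1-fold higher number from compound 2 to compound 1 (0.04 log units; within the scatter). Compound 4 carries the same change from compound 3, (4-chlorophenyl in place of 3,5-dimethoxyphenyl on a nitrogen on an aromatic ring), at the same place. Because the step of a 1.1-fold higher number from compound 2 to compound 1 (0.04 log units; within the scatter) lay within the scatter, compound 4 is expected to show a 1.1-fold higher number from compound 3 to compound 4 (0.05 log units; within the scatter). In this assay compound 4 is estimated at 2700 nM, within a range from 1300 nM to 5600 nM.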

Compound 4, concentration for 50% growth inhibition: 2700 nM
For compound 4 middle estimate and measured number coincide at the digits printed, and the stated range covers the measured number.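

In this assay, 4-chlorophenyl in place of 3,5-dimethoxyphenyl gave a 1.1-fold higher number from compound 3 to compound 4 (0.05 log units; within the scatter), which agrees with the same exchange on the other core: the same change on two cores in this assay, a 1.1-fold higher number (0.04 log units; within the scatter) from compound 2 to compound 1 and a 1.1-fold higher number (0.05 log units; within the scatter) from compound 3 to compound 4, 1.0-fold (0.01 log units) apart, within the scatter of two such steps. Hydrogen in place of ethyl on the saturated chain gave a 1.3-fold higher number from compound 1 to compound 4 (0.11 log units; within the scatter), which also agrees with its earlier counterpart: the same change on two cores in this assay, a 1.3-fold higher number (0.10 log units; within the scatter) from compound 2 to compound 3 and a 1.3-fold higher number (0.11 log units; within the scatter) from compound 1 to compound 4, 1.0-fold (0.01 log units) apart, within the scatter of two such steps. Among these compounds, each step lies within the scatter, so this agreement shows only that neither change separates these four compounds in this assay; it does not show that a step of larger size would carry from one core to another, or that the agreement extends beyond these cores.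

From the compounds shown here alone, it remains open whether a phenyl ring bearing an amine or a carboxylic acid in place of the chlorine, or a longer chain, would give a step beyond the scatter.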